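Removing a Fluorine Atom on a Potent Stereoisomer

The source may hold more compounds than are shown below. What is called first, only, known or untested is meant among the compounds shown, and "the series" means these compounds.

Measured compounds in a functional assay on HCC827 cells (Homo sapiens) for antiproliferative activity, read by MTT assay, with a stated time of 72 h; on this read-out higher numbers stand for weaker inhibition and lower numbers for stronger inhibition:
compound 1 `CN1CCN(c2ccc(Nc3ncc4nc(Nc5ccccc5)n([C@H]5CCN(C(=O)OC(C)(C)C)C5)c4n3)cc2)CC1` gives 110 nM
compound 2 `CN1CCN(c2ccc(Nc3ncc4nc(Nc5ccc(F)cc5)n([C@H]5CCN(C(=O)OC(C)(C)C)C5)c4n3)cc2)CC1` gives 580 nM
compound 3 `CN1CCN(c2ccc(Nc3ncc4nc(Nc5ccc(F)cc5)n([C@@H]5CCN(C(=O)OC(C)(C)C)C5)c4n3)cc2)CC1` gives 27 nM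

Compound 4 `CN1CCN(c2ccc(Nc3ncc4nc(Nc5ccccc5)n([C@@H]5CCN(C(=O)OC(C)(C)C)C5)c4n3)cc2)CC1` has not yet been measured. It differs from compound 3 by hydrogen in place of fluoro on an aromatic carbon. The same change has been made once already, from compound 2 to compound 1, as hydrogen in place of fluoro on an aromatic carbon, and there it produced a 5.3-fold lower number from compound 2 to compound 1 (0.72 log units; beyond the scatter) in this assay. The two cores differ by the two compounds have the same atoms and bonds and differ only in configuration as drawn: 1 of 1 stereo elements differ; a stereocentre at a saturated ring carbon is drawn S in compound 2 and R in compound 3; that single change in configuration gave a 21-fold lower number from compound 2 to compound 3 (1.33 log units; beyond the scatter), which rests on (the fact that compounds 2 and 3 differ only in the configuration as drawn). Compound 3 already stands lowest of the three measured compounds. If the change behaves as it did from compound 2 to compound 1, compound 4 is expected to show a 3.4-fold lower number from compound 3 to compound 4 (0.53 log units; beyond the scatter) in this assay. Compound 4 is therefore estimated at 8 nM, with a likely range from 3 nM to 25 nM.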

Compound 4, half-maximal inhibitory concentration: 12 nM
Beside the measured number, compound 4's estimate is 1.5-fold (0.18 log units) below it; low and high end bracket the measured number.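

In this assay replacing fluoro with hydrogen on the core drawn R again lowers the number (a 2.3-fold lower number from compound 3 to compound 4 (0.35 log units; beyond the scatter)), and the two steps for this change do not differ beyond the scatter: the same change on two cores in this assay, a 5.3-fold lower number (0.72 log units; beyond the scatter) from compound 2 to compound 1 and a 2.3-fold lower number (0.35 log units; beyond the scatter) from compound 3 to compound 4, 2.3-fold (0.37 log units) apart, within the scatter of two such steps. The configuration also still matters without the fluoro group (a 9.2-fold lower number from compound 1 to compound 4 (0.96 log units; beyond the scatter)), and only the drawn configuration separates this pair: the fact that compounds 1 and 4 differ only in the configuration as drawn. So the change carried over between these two stereoisomeric cores in direction and, within the scatter, in size, but two pairs in one cell assay cannot show that it would hold on a different core, nor why the number falls.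

The compounds shown leave open whether chloro or methoxy in that place would behave like fluoro or like hydrogen. They also leave open whether the same steps would appear with a free amine in place of the tert-butyl carbamate.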